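Swapping an Aromatic Ring for a Branched Chain

A few compounds are considered here, and "the series" means these few. Any claim that something is new, unique, unknown or untested is made for them only; others in the source may bear on it.

Of the compounds shown here, three that share one core have been measured in a physicochemical assay for solubility, read by HPLC; on this read-out lower numbers stand for lower solubility and higher numbers for higher solubility. Compound 1 `O=C(c1ccc(Cl)cc1)N1CCN(c2nc(=O)c3cc(C(F)(F)F)cc([N+](=O)[O-])c3s2)CC1` gives 5.19 ug/mL. Compound 2 `CCCC(=O)N1CCN(c2nc(=O)c3cc(C(F)(F)F)cc([N+](=O)[O-])c3s2)CC1` gives 2.46 ug/mL. Compound 3 `Cc1ccc(C(=O)N2CCN(c3nc(=O)c4cc(C(F)(F)F)cc([N+](=O)[O-])c4s3)CC2)cc1` gives 6.7 ug/mL, the highest of the three numbers, though its gap to compound 1 lies within the scatter, a 1.3-fold higher number from compound 1 to compound 3 (0.11 log units; within the scatter), and only its gap to compound 2 lies beyond it, a 2.7-fold higher number from compound 2 to compound 3 (0.44 log units; beyond the scatter).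

Compound 4 `CC(C)(C)C(=O)N1CCN(c2nc(=O)c3cc(C(F)(F)F)cc([N+](=O)[O-])c3s2)CC1` has not been measured yet. It differs from compound 3 in one place: tert-butyl in place of 4-methylphenyl on a carbonyl carbon. Among the measured compounds shown here, two measured steps bear on this, since each exchanges, on that same carbonyl carbon, a six-membered aromatic ring for a short chain or the reverse. Putting a chain in place of a ring gave a 2.1-fold lower number from compound 1 to compound 2 (0.32 log units; beyond the scatter), and putting a ring in place of a chain gave a 2.7-fold higher number from compound 2 to compound 3 (0.44 log units; beyond the scatter). Both steps are modest and point the same way: the chain goes with the lower number. Compound 4 is therefore expected to land somewhat below compound 3, a step estimated as a 2.2-fold lower number from compound 3 to compound 4 (0.35 log units; beyond the scatter). The estimate for compound 4 in this assay is 3 ug/mL, expected to fall between 1.5 ug/mL and 6 ug/mL.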

Compound 4, solubility: 5.87 ug/mL
Compound 4: the middle estimate sits 2.0-fold (0.29 log units) below what was measured; low and high end bracket the measured number.
By their numbers in this assay, from the lowest: compound 2; then compounds 1, 4 and 3 (each within the scatter of the next).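

In this assay a ring on this carbonyl carbon proves not to be required for a number in the range of the ring compounds: tert-butyl, which has no ring, cannot be told apart from 4-methylphenyl (a 1.1-fold lower number from compound 3 to compound 4 (0.06 log units; within the scatter)) or from 4-chlorophenyl (a 1.1-fold higher number from compound 1 to compound 4 (0.05 log units; within the scatter)). The earlier picture, in which the chain went with the lower number, rested on propyl alone, and here two groups without a ring part ways, since tert-butyl in place of propyl gives a clear, though modest, step (a 2.4-fold higher number from compound 2 to compound 4 (0.38 log units; beyond the scatter)), leaving compound 2 as the only one of the four that stands apart. Nothing measured here explains why propyl and tert-butyl differ on this carbonyl carbon.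

The compounds shown leave open whether a longer straight chain such as pentyl, or a smaller branched one such as isopropyl, would sit with compound 2 or with compound 4. They also leave open whether a group carrying an amine or a carboxylic acid on this carbonyl carbon would move the number clear of all four compounds.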